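The source may report more compounds than this note shows. Statements on the series, on what has been measured and on what is new or still open speak of the compounds shown alone.

In a functional assay on MCF7 cells (Homo sapiens) for antiproliferative activity, read by MTT assay, with a stated time of 48 h (on this read-out lower numbers stand for stronger inhibition and higher numbers for weaker inhibition), compound 1 (`O=C(/C=C/c1ccc([N+](=O)[O-])cc1)N1Cc2ccccc2[C@@H](OCc2ccccc2)[C@@H]1CO`) gives 24400 nM and compound 2 (`Cc1ccc(S(=O)(=O)NCC(=O)N2Cc3ccccc3[C@@H](OCc3ccccc3)[C@@H]2CO)cc1`) gives 11500 nM while compound 3 (`Cc1ccc(S(=O)(=O)N[C@@H](C)C(=O)N2Cc3ccccc3[C@@H](OCc3ccccc3)[C@@H]2CO)cc1`) gives 14800 nM and so sits within the scatter of both. Compound 4 (`Cc1ccc(S(=O)(=O)N[C@H](C(=O)N2Cc3ccccc3[C@@H](OCc3ccccc3)[C@@H]2CO)C(C)C)cc1`) carries isopropyl in place of methyl on a saturated chain carbon bound to a carbonyl carbon and a sulfonamide nitrogen. Among the compounds with values here, the one measured step at that place, methyl in place of hydrogen, stays within the scatter (a 1.3-fold higher number from compound 2 to compound 3 (0.11 log units; within the scatter)). That single step is thin evidence for isopropyl, but in this assay no shift beyond the scatter is expected (a 1.1-fold lower number from compound 3 to compound 4 (0.06 log units; within the scatter)). For compound 4 the estimate is 13000 nM (estimated range 6000 nM to 28000 nM).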

Compound 4, half-maximal inhibitory concentration: 60400 nM
Estimate against measurement, compound 4: 4.6-fold (0.67 log units) below; measured number outside the range, above it.
By their numbers in this assay, from the lowest: compounds 2, 3 and 1 (each within the scatter of the next, the first and the last beyond it); then compound 4.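

The position is not indifferent to what it carries: the smaller change had stayed within the scatter (a 1.3-fold higher number from compound 2 to compound 3 (0.11 log units; within the scatter)), but isopropyl in place of methyl on the saturated chain carbon weakens inhibition beyond it (a 4.1-fold higher number from compound 3 to compound 4 (0.61 log units; beyond the scatter)). Isopropyl in place of hydrogen at the same place also goes beyond the scatter (a 5.3-fold higher number from compound 2 to compound 4 (0.72 log units; beyond the scatter)). The loss therefore appears only with isopropyl, not with methyl.

As far as these compounds go, whether a longer straight chain, an amine or a carboxylic acid at this place would keep the number of compound 3 remains open. Nothing available accounts for the weaker inhibition of compound 4.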